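Swapping nitro for amino on an ester-linked analogue

The source may report more compounds than this note shows. Statements on the series, on what has been measured and on what is new or still open speak of the compounds shown alone.

Measured compounds in a functional assay on HCT-15 cells (Homo sapiens) for antiproliferative activity, read by MTT assay, with a stated time of 72 h; on this read-out higher numbers stand for weaker inhibition and lower numbers for stronger inhibition:
- compound 1, `COc1ccc(NC(=O)c2cc(OC)c(OC)c(OC)c2)cc1[N+](=O)[O-]`, gives 17600 nM
- compound 2, `COc1ccc(NC(=O)c2cc(OC)c(OC)c(OC)c2)cc1N`, gives 6500 nM
- compound 3, `COc1ccc(C(=O)Oc2cc(OC)c(OC)c(OC)c2)cc1[N+](=O)[O-]`, gives only a limit, > 100000 nM

Compound 1 and compound 2 share a core and differ in one place: amino in place of nitro on an aromatic carbon. This change gives a 2.7-fold lower number from compound 1 to compound 2 (0.43 log units; beyond the scatter), so the amino compound is the more potent of the pair in this assay.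

Compound 3 carries a different core, and the difference between the two cores is not broken down here. Its value in this assay is not a number but a limit, the one shown at the limit of > 100000 nM in this assay, at which 1 of the 3 values shown sits.

Compound 4, `COc1ccc(C(=O)Oc2cc(OC)c(OC)c(OC)c2)cc1N`, is not yet measured. It relates to compound 3 as compound 2 relates to compound 1: amino in place of nitro on an aromatic carbon. The place of the change is the same word for word in both pairs, so this is the same change.

Among the measured compounds shown here, the only measured guide is the step from compound 1 to compound 2, a 2.7-fold lower number from compound 1 to compound 2 (0.43 log units; beyond the scatter). Starting from a limit, the result could again be a limit. For compound 4 in this assay, a step of an at least 1.6-fold lower number from compound 3 to compound 4 (0.22 log units; that floor lies within the scatter) is expected, resting on the step from compound 1 to compound 2. Compound 4 is estimated at 60000 nM, within 20000 nM to 250000 nM.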

Compound 4, half-maximal inhibitory concentration: > 100000 nM
Compound 4: a limit, no number (the forecaster's own chance of this, stated with the estimate: 45%); middle value at least 1.6-fold (0.22 log units) away from the limit.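

In this assay, compound 4 gives a limit and not a number, and so does compound 3, so the step between these two compounds cannot be read: the limit of > 100000 nM in this assay, at which 2 of the 4 values shown sit.

The compounds shown leave open whether amino in place of nitro changes potency at all on the core of compound 3, and whether any such change would match the one seen on the core of compound 1.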